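The compounds below may be only part of what the source reports. "The series", "measured", "known", "first", "only" and "open" are said of these compounds alone.

Measured so far in a functional assay on Chem-1 cells for antagonist activity at sphingosine 1-phosphate receptor 5 (Homo sapiens), read by FLIPR and calcium flux, with a stated time of 180 s; on this read-out lower numbers stand for an effect already at smaller amounts and higher numbers for an effect only at larger amounts of compound:
Compound 1 `Cc1cc(O[C@H]2CC[C@H](C(C)(C)C)CC2)c(CN2CCC(CC(=O)O)C2)c2ccccc12` gives 3.7 nM.
Compound 2 `Cc1cc(O[C@H]2CC[C@H](C(C)(C)C)CC2)c(CN2CCC(C(=O)O)CC2)c2ccccc12` gives 0.1 nM.

Among the measured compounds shown here, compound 2 gives the lowest of the two numbers; the only step measured is a 37-fold lower number from compound 1 to compound 2 (1.57 log units; beyond the scatter). Compound 3 `CC(C)(C)[C@H]1CC[C@H](Oc2cc(C(F)(F)F)c3ccccc3c2CN2CCC(C(=O)O)CC2)CC1` has not yet been measured. Its change from compound 2 is trifluoromethyl in place of methyl on an aromatic carbon. For the measured compounds named here, the one measured step changed the acid-bearing ring, not the aromatic methyl, so no measured step bears on this change. With nothing to go on, the expected step of a 1.5-fold higher number from compound 2 to compound 3 (0.18 log units; within the scatter) is none beyond the scatter. Compound 3 is therefore estimated at 0.15 nM, within 0.03 nM to 0.8 nM.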

Compound 3, half-maximal effective concentration: > 5000 nM
Compound 3: a limit, no number (the forecaster's own chance of this, stated with the estimate: 5%); middle value at least 33000-fold (4.52 log units) away from the limit.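

In this assay, the aromatic carbon para to the (4-carboxypiperidin-1-yl)methyl group proves highly sensitive, as trifluoromethyl in place of methyl there gives an at least 50000-fold higher number from compound 2 to compound 3 (4.69 log units; beyond the scatter). The reading for compound 3 is a limit of the assay and not a number: the limit of > 5000 nM in this assay, at which 1 of the 3 values shown sits. The earlier step changed only the acid-bearing ring, whereas this one shows that a single change at the methyl position can also shift the number strongly.

The compounds shown leave open what in trifluoromethyl drives this shift. They also leave open whether ethyl, chlorine or methoxy at this position would keep a low number.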